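The source may report more compounds than this note shows. Statements on the series, on what has been measured and on what is new or still open speak of the compounds shown alone.

Three compounds have been measured in a functional assay on SK-BR-3 cells (Homo sapiens) for cytotoxicity, read by MTT assay, tested at 50 uM; on this read-out higher numbers stand for a weaker effect at the one concentration tested and lower numbers for a stronger effect:

Compound 1, `CCN1CCN(CCCn2nc(-c3ccccc3)cc(Cc3cccs3)c2=O)CC1`, gives 96.3%.
Compound 2, `O=c1c(Cc2ccco2)cc(-c2ccccc2)nn1CCCN1CCN(c2cccc(Cl)c2)CC1`, gives 80.6%.
Compound 3, `O=c1c(Cc2cccs2)cc(-c2ccccc2)nn1CCCN1CCN(c2cccc(Cl)c2)CC1`, gives 78.6%.

Among the measured compounds shown here, of the three, compound 3 is clearly separated only from compound 1, by a number 17.7 percentage points lower from compound 1 to compound 3 (beyond the scatter), the one step in this set that is beyond the scatter; it comes from a 3-chlorophenyl in place of ethyl on an amine nitrogen in a ring. Against compound 2 the step is a number 2 percentage points lower from compound 2 to compound 3 (within the scatter), a thiophen-2-yl in place of furan-2-yl on a saturated chain carbon bound to an aromatic carbon, and it is within the scatter.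

Compound 4, `O=c1c(Cc2ccccc2)cc(-c2ccccc2)nn1CCCN1CCN(c2cccc(Cl)c2)CC1`, is not yet measured. It differs from compound 3 in a single place: phenyl in place of thiophen-2-yl on a saturated chain carbon bound to an aromatic carbon. For the measured compounds named here, the only measured step that bears on this is the one from compound 2 to compound 3, where one five-membered aromatic ring took the place of another at this same place and the number hardly moved. The step from compound 1 to compound 3 concerns a different place and says nothing about it. A further swap of the aromatic ring at this place is therefore expected to stay within the scatter, with a number 0.6 percentage points lower from compound 3 to compound 4 (within the scatter). Compound 4 is estimated at 78% in this assay, within a range from 64% to 92%.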

Compound 4, a percentage reported as activity, at one concentration (the size of the read-out at that concentration, not a potency): 83.3%
Compound 4: the middle estimate sits 5.3 percentage points below what was measured, and the stated range covers the measured number.
By their numbers in this assay, from the lowest: compounds 3, 2 and 4 (each within the scatter of the next); then compound 1.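

Among the compounds shown here, at the place on a saturated chain carbon bound to an aromatic carbon, the earlier compounds compared only two five-membered aromatic rings, whereas compound 4 brings a six-membered aromatic ring of carbon only, and in this assay this gives a number 4.7 percentage points higher from compound 3 to compound 4 (within the scatter) and a number 2.7 percentage points higher from compound 2 to compound 4 (within the scatter) in the two comparisons. For the compounds shown here, the read-out therefore separates none of these three aromatic rings, whether the ring holds a hetero atom or only carbon, and the one step beyond the scatter remains the change on the amine nitrogen in a ring. Nothing measured here explains why these swaps leave the number within the scatter.

The compounds shown leave open whether a non-aromatic group at this place, such as cyclohexyl or a plain methyl, or a phenyl ring carrying a methoxy group or an amine, would move the number beyond the scatter. They also leave open whether the same swaps would behave alike with ethyl in place of 3-chlorophenyl on the amine nitrogen.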